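Notes on one aromatic group exchange in the series

The source may hold more compounds than are shown below. What is called first, only, known or untested is meant among the compounds shown, and "the series" means these compounds.

In an ADME assay (liver) for metabolic stability, with Liver microsome (Rattus norvegicus) as the target, using microsomes and NADPH, with a stated time of 30 min, tested at 1 uM (a higher number here means faster removal of the compound, a lower number slower removal), compound 1 `Cn1cc(-c2cc(C(O)(C(F)(F)F)C(F)(F)F)cnc2N2CCN(S(=O)(=O)c3ccc(N)nc3)CC2)cn1` gives 44 mL.min-1.g-1 and compound 2 `NC(=O)c1cccc(-c2cc(C(O)(C(F)(F)F)C(F)(F)F)cnc2N2CCN(S(=O)(=O)c3ccc(N)nc3)CC2)c1` gives 63 mL.min-1.g-1. These two values lie within the scatter of each other, so compound 2 holds no distinct place on the numbers available. The next change leads to compound 3 `Cc1ccc(-c2cc(C(O)(C(F)(F)F)C(F)(F)F)cnc2N2CCN(S(=O)(=O)c3ccc(N)nc3)CC2)cn1`, with 6-methylpyridin-3-yl in place of 3-carbamoylphenyl on an aromatic carbon. Among the measured compounds shown here, one measured step bears on this change: a 1.4-fold higher number from compound 1 to compound 2 (0.16 log units; within the scatter). It exchanges one aromatic group for another at the same carbon and stays within the scatter. For the measured compounds named here, no measured compound carries 6-methylpyridin-3-yl, so this single step is the only guide to size. No step beyond the scatter is therefore expected in this assay, and no firm direction can be drawn. The expected step is small, a 1.3-fold lower number from compound 2 to compound 3 (0.10 log units; within the scatter). For compound 3 the estimated value is 50 mL.min-1.g-1, with an expected range of 25 mL.min-1.g-1 to 100 mL.min-1.g-1.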

Compound 3, intrinsic clearance in microsomes: 182 mL.min-1.g-1
Beside the measured number, compound 3's estimate is 3.6-fold (0.56 log units) below it; the whole stated range lies below it.
By their numbers in this assay, from the lowest: compounds 1 and 2 (each within the scatter of the next); then compound 3.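

In this assay this aromatic carbon, ortho to a large group and meta to a 2,2,2-trifluoro-1-hydroxy-1-(trifluoromethyl)ethyl group, now shows that an exchange of one aromatic group for another can carry the intrinsic clearance beyond the scatter: 6-methylpyridin-3-yl in place of 3-carbamoylphenyl gives a 2.9-fold higher number from compound 2 to compound 3 (0.46 log units; beyond the scatter), and 6-methylpyridin-3-yl in place of 1-methyl-1H-pyrazol-4-yl gives a 4.1-fold higher number from compound 1 to compound 3 (0.62 log units; beyond the scatter). While 1-methyl-1H-pyrazol-4-yl and 3-carbamoylphenyl stay within the scatter of each other, 6-methylpyridin-3-yl stands apart from both, so the read-out at this position does depend on the group it carries. Both steps are modest, and three compounds give one separation rather than a trend across the series. No measurement at hand accounts for the higher number, and its origin stays unassigned.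

From the compounds shown here alone, whether the higher number goes with the methyl group of 6-methylpyridin-3-yl or with the ring that carries it remains open; a plain pyridin-3-yl at this carbon would separate the two. Also open, going by these compounds, is how an amine or a methoxy group in place of that methyl, or a carboxylic acid in place of the carbamoyl group, would stand in this read-out.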